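The source may report more compounds than this note shows. Statements on the series, on what has been measured and on what is new or still open speak of the compounds shown alone.

Measured so far in a functional assay on TA3 cells (Mus musculus) for inhibition, with a stated time of 3 days, in the presence of a further agent that is not named here; a lower number here means a stronger inhibitor, a higher number a weaker inhibitor
compound 1 (`C=Cc1ncc(CO)c(C=C)c1O`) gives 6.8 uM
compound 2 (`Cc1c(CO)cnc(/C=N/NC(N)=S)c1O`) gives 2.7 uM

Compound 1 has the higher of the two numbers, which makes it the weaker inhibitor of this pair, and its gap to compound 2 lies beyond the scatter. The two compounds differ in more than one place, so that gap says nothing about the next change. The next compound to be measured is compound 3 (`C=Cc1ncc(CO)c(CO)c1O`). It keeps the core of compound 1, with hydroxymethyl in place of vinyl on an aromatic carbon, opposite the ring nitrogen (hydroxymethyl in place of vinyl on an aromatic carbon). Within the data shown here, no measured pair shows a change of this kind, so the expectation is only a judgement: a moderately higher number in this assay, with a step within the scatter not excluded. The expected step (a 2.1-fold higher number from compound 1 to compound 3 (0.31 log units; beyond the scatter)) is an estimate only. Compound 3 is estimated at 14 uM (expected range 5 uM to 40 uM).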

Compound 3, concentration for 50% inhibition: 9.4 uM
For compound 3 the middle estimate is 1.5-fold (0.17 log units) above the measured one; low and high end bracket the measured number.
By their numbers in this assay, from the lowest: compound 2; then compounds 1 and 3 (each within the scatter of the next).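

In this assay, among these compounds, hydroxymethyl in place of vinyl on the aromatic carbon opposite the ring nitrogen gives a 1.4-fold higher number from compound 1 to compound 3 (0.14 log units; within the scatter), the first step that can be read at a single place. At this position, the exchange of vinyl for hydroxymethyl, which adds a hydrogen-bond donor and a hydrogen-bond acceptor, leaves the read-out within the scatter, so this pair gives no sign that vinyl is required there. No available data account for this outcome.

The compounds shown leave open whether an aminomethyl group, a carboxylic acid or a longer chain at this position would also stay within the scatter of compound 1. They also leave open what the remaining vinyl group of compound 3 contributes to the read-out.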